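The source may hold more compounds than are shown below. What is called first, only, known or untested is meant among the compounds shown, and "the series" means these compounds.

Within the data shown here, compound 2, `Cc1ccc(C2=CC(c3cc4cc(Cl)ccc4nc3Cl)NC(SCCC#N)=N2)cc1`, is the only compound here with a number rather than a limit in a functional assay on HeLa cells (Homo sapiens) for cytotoxicity, read by MTT assay, with a stated time of 24 h; on this read-out lower numbers stand for stronger inhibition and higher numbers for weaker inhibition: in that test compound 2 gives 94200 nM. Compound 1, `N#CCCSC1=NC(c2ccc(O)cc2)=CC(c2cc3cc(Cl)ccc3nc2Cl)N1`, gives in this assay only a limit, > 100000 nM, so no exact number is known for it. Among the measured compounds shown here, the one measured step, an at least 1.0-fold lower number from compound 1 to compound 2 (0.02 log units; that floor lies within the scatter), cannot be sized properly because one of its ends is the limit of > 100000 nM in this assay, at which 1 of the 2 values shown sits. Compound 3, `COc1ccc(C2=CC(c3cc4cc(Cl)ccc4nc3Cl)NC(SCCC#N)=N2)cc1`, is reached from compound 2 by a single small change: methoxy in place of methyl on an aromatic carbon. For the measured compounds named here, the only measured step concerns the same aromatic carbon but exchanges hydroxy for methyl, and it gives no sign that swapping one small group for another at this position moves the read-out beyond the scatter. Nothing in the measured data points in either direction for a methoxy at this place. The expected step is therefore a 1.1-fold higher number from compound 2 to compound 3 (0.03 log units; within the scatter), within the scatter. Compound 3 is estimated at 100000 nM, with a range from 40000 nM to 250000 nM, and a real chance that only a limit is reported.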

Compound 3, half-maximal inhibitory concentration: > 100000 nM
Compound 3: only a limit was reported; the forecaster's own chance of this, stated with the estimate: 50%; the middle value lies on the limit itself.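

Going from methyl to methoxy at this place gives an at least 1.0-fold higher number from compound 2 to compound 3 (0.02 log units; that floor lies within the scatter), so in this assay this swap, like the earlier one from hydroxy to methyl, shows no move that can be told apart from the scatter. Compound 3 now joins compound 1 at the limit of the test, and the step between compound 1 and compound 3 cannot be read, nor can the true size of the other steps be fixed, because their ends are limits rather than numbers: the limit of > 100000 nM in this assay, at which 2 of the 3 values shown sit. Across compound 1, compound 2 and compound 3, none of the three groups on this aromatic carbon brings the read-out clearly below that limit, which the single earlier step could not show.

Going by these compounds, how far compound 1 and compound 3 really lie beyond the limit stays unknown, so it remains open whether hydroxy, methyl and methoxy truly differ here. Also open, on these data alone, is whether a different group at this carbon, such as an amine or a carboxylic acid, or a longer chain on the sulfur of the shared core, would give a clearly lower number.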